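Cytotoxicity notes on the series: compound 2 to compound 4

The compounds below may be only part of what the source reports. "The series", "measured", "known", "first", "only" and "open" are said of these compounds alone.

Three compounds of the series, compound 1 `CCCCCN1C(=O)C/C(=C\c2cccc(C(=O)Nc3ccc(C)cc3)c2)C1=O`, compound 2 `Cc1ccc(NC(=O)c2cccc(/C=C3\CC(=O)N(c4ccccc4)C3=O)c2)cc1C` and compound 3 `COc1ccc(NC(=O)c2cccc(/C=C3\CC(=O)N(c4ccc(C)cc4)C3=O)c2)cc1`, have been run in an ADME assay on NCM460 cells (Homo sapiens) for cytotoxicity, read by MTT assay, with a stated time of 72 h; a higher number here means a weaker inhibitor, a lower number a stronger inhibitor. In this assay compound 1 gives only a limit, > 100000 nM. Compound 2 likewise returns a limit, > 100000 nM. Compound 3 also sits at a limit, > 100000 nM. Where compound 2 stands is therefore known only as a bound: all values shown rest at the same limit, (the limit of > 100000 nM in this assay, at which 3 of the 3 values shown sit), so no ranking among the three can be drawn, and no step between two measured compounds is available.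

Compound 4 `O=C(Nc1cccc(F)c1)c1cccc(/C=C2\CC(=O)N(c3ccccc3)C2=O)c1` is not yet measured. It differs from compound 2 by 3-fluorophenyl in place of 3,4-dimethylphenyl on an amide-type nitrogen. With every measured compound sitting at the limit, the step from compound 2 to compound 4 is expected to show no change beyond the scatter, a step that the limit leaves unreadable from compound 2 to compound 4. For compound 4 in this assay the estimate is 150000 nM, with a range from 50000 nM to 500000 nM, and a strong chance that the assay again reports only a limit.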

Compound 4, half-maximal inhibitory concentration: > 100000 nM
Compound 4: only a limit was reported; the forecaster's own chance of this, stated with the estimate: 85%; the middle value is on the limit's open side.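

No step can be read from compound 2 to compound 4, because both results are limits: the limit of > 100000 nM in this assay, at which 4 of the 4 values shown sit.

The compounds shown leave open whether any member of the series reaches a measurable value in this assay, and how the groups on the amide-type nitrogen would rank there.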